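This account rests on a few compounds, and the source may have more. Where it says the series, first, only, none or still open, it means among the compounds named here.

Compound 1 `CCCOC(=O)C1=C(C)NC(=O)NC1c1ccoc1`: 11%
Compound 2 `CC(=O)C1=C(C)NC(=O)NC1c1ccoc1`: 2%
Compound 3 `CC1=C(C(N)=O)C(c2ccoc2)NC(=O)N1`: 2%

In an assay on membranes from HeLa cells for displacement of a labelled ligand from adenosine receptor A3 (Homo sapiens), read by scintillation counting, with a stated time of 180 min, tested at 1 uM (a higher number here means more inhibition at the concentration tested (going by the name of the read-out), a lower number less inhibition), compound 3 stands level with compound 2 at the digits shown, the two together being the lowest of the three numbers; the steps of no change at the digits printed from compound 2 to compound 3 (within the scatter) and a number 9 percentage points lower from compound 1 to compound 3 (within the scatter) both lie within the scatter. Compound 4 `CC1=C(C(=O)NC(C)C)C(c2ccoc2)NC(=O)N1` differs from compound 3 by isopropyl in place of hydrogen on an amide-type nitrogen. Going by the values given here, no measured step touches the amide-type nitrogen; the three known steps, a number 9 percentage points lower from compound 1 to compound 2 (within the scatter), a number 9 percentage points lower from compound 1 to compound 3 (within the scatter) and no change at the digits printed from compound 2 to compound 3 (within the scatter), all exchange groups on the carbonyl carbon and none leaves the scatter. The step is therefore expected to be a number 2 percentage points higher from compound 3 to compound 4 (within the scatter), without change beyond the scatter. For compound 4 the estimate is 4%, in a range from -8% to 16%.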

Compound 4, a percentage reported as inhibition, at one concentration (the size of the read-out at that concentration, not a potency): 3%
For compound 4 the middle estimate is 1 percentage points above the measured one; the measured number falls inside the stated range.
By their numbers in this assay, from the lowest: compounds 2, 3, 4 and 1 (each within the scatter of the next).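

Isopropyl in place of hydrogen on the amide-type nitrogen gives a number 1 percentage points higher from compound 3 to compound 4 (within the scatter) in this assay and is the first change shown at this nitrogen, which takes the added group with no shift that stands out from the scatter. Isopropylamino on the carbonyl carbon likewise gives a number 1 percentage points higher from compound 2 to compound 4 (within the scatter) against methyl and a number 8 percentage points lower from compound 1 to compound 4 (within the scatter) against propoxy, so no group yet tried at this carbonyl carbon separates from the others. No supporting evidence bears on these results. From the compounds shown here alone, whether a longer chain, a phenyl ring or a terminal amine on this nitrogen would move the number beyond the scatter remains open.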